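Aryl substituent swap on the shared core

The compounds below may be only part of what the source reports. "The series", "measured", "known", "first", "only" and "open" are said of these compounds alone.

Among the measured compounds shown here, the series so far holds two measured compounds. Compound 1 `Cc1cc(NC(=O)Cn2nnc(-c3ccc(F)cc3)n2)n(C2CCCCC2)n1` gives 180 nM in an assay on HEK293 cells for activation of Kir3.1/Kir3.2 (Homo sapiens), read by thallium flux; a lower number here means that less compound is needed, a higher number that more compound is needed for the effect. Compound 2 `Cc1cc(NC(=O)Cn2nnc(-c3ccccc3F)n2)n(C2CCCCC2)n1` gives 187 nM in this assay. The single measured step, a 1.0-fold higher number from compound 1 to compound 2 (0.02 log units; within the scatter), leaves the two within the scatter of each other, so compound 2 stands level with compound 1 on the numbers shown and no order between them can be claimed.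

Compound 3 `COc1ccc(-c2nnn(CC(=O)Nc3cc(C)nn3C3CCCCC3)n2)cc1` is not yet measured. Its change from compound 2 is 4-methoxyphenyl in place of 2-fluorophenyl on an aromatic carbon. For the measured compounds named here, the only measured step touching this part of the structure, a 1.0-fold higher number from compound 1 to compound 2 (0.02 log units; within the scatter), exchanged one fluorophenyl for another without a change beyond the scatter. Going by the values given here, no measured step covers the methoxy group itself, so its direction is open. The expected step in this assay is a 1.1-fold higher number from compound 2 to compound 3 (0.05 log units; within the scatter), not beyond the scatter. Compound 3 is therefore estimated at 210 nM, with a range of 80 nM to 550 nM.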

Compound 3, half-maximal effective concentration: 175 nM
Compound 3: the middle estimate sits 1.2-fold (0.08 log units) above what was measured; low and high end bracket the measured number.
By their numbers in this assay, from the lowest: compounds 3, 1 and 2 (each within the scatter of the next).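

In this assay, a 1.1-fold lower number from compound 2 to compound 3 (0.03 log units; within the scatter) and a 1.0-fold lower number from compound 1 to compound 3 (0.01 log units; within the scatter) extend the flat picture from an exchange of one fluorophenyl for another to an exchange of the substituent itself: on this aromatic carbon of a five-membered aromatic ring with 4 nitrogen, 4-methoxyphenyl stands level with both fluorophenyl compounds. The oxygen and the hydrogen-bond acceptor counted on 4-methoxyphenyl, neither of which is present on 2-fluorophenyl, come with no step beyond the scatter. No measurement available here accounts for this level reading.

As far as these compounds go, an amine, a carboxylic acid or a longer alkoxy chain on this phenyl ring remains open. Also open, from the compounds shown here alone, is whether any replacement at this position gives a step beyond the scatter, as all steps among compound 1, compound 2 and compound 3 lie within it.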